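The source may hold more compounds than are shown below. What is called first, only, known or untested is meant among the compounds shown, and "the series" means these compounds.

In a functional assay on MCF7 cells (Homo sapiens) for antiproliferative activity, read by MTT assay, with a stated time of 48 h (a lower number here means a stronger inhibitor, a higher number a weaker inhibitor), compound 1 `Clc1ccc2[nH]c(-c3cn(-c4ccccc4)nc3-c3ccccc3)nc2c1` gives 1960 nM and compound 2 `COc1ccc(-c2nn(-c3ccccc3)cc2-c2nc3cc(Cl)ccc3[nH]2)cc1` gives 1760 nM. Among the measured compounds shown here, the one measured step, a 1.1-fold lower number from compound 1 to compound 2 (0.05 log units; within the scatter), comes from methoxy in place of hydrogen on an aromatic carbon and lies within the scatter, so compound 2 stands level with compound 1 on these numbers.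

Compound 3 `COc1ccc(-c2nn(-c3ccccc3)cc2-c2nc3cc(C(=O)OCc4ccccc4)ccc3[nH]2)cc1` keeps the methoxy of compound 2 but carries benzyloxycarbonyl in place of chloro on an aromatic carbon. The measured step concerns a different place on the molecule, and its size says little about this swap. For the measured compounds named here, no measured pair varies the chloro, and the incoming group is far larger, so the data give no direction for the change. The best guess in this assay is therefore no step beyond the scatter, with real room on either side, anchored on compound 2 at 1760 nM. The expected change is small, a 1.2-fold lower number from compound 2 to compound 3 (0.07 log units; within the scatter). Compound 3 is estimated at 1500 nM, with an expected range of 400 nM to 6000 nM.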

Compound 3, half-maximal inhibitory concentration: 7460 nM
Compound 3: the middle estimate sits 5.0-fold (0.70 log units) below what was measured; measured number outside the range, above it.
By their numbers in this assay, from the lowest: compounds 2 and 1 (each within the scatter of the next); then compound 3.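

The place held by chloro, on an aromatic carbon of the six-membered ring in the fused system of two rings, is not indifferent to change: in this assay, benzyloxycarbonyl in place of chloro gives a 4.2-fold higher number from compound 2 to compound 3 (0.63 log units; beyond the scatter). The earlier pair showed nothing of this kind, since it varied another part of the molecule and its step, a 1.1-fold lower number from compound 1 to compound 2 (0.05 log units; within the scatter), stayed within the scatter, so this swap is the first shown to weaken the compound measurably. No accompanying measurement shows which feature of the incoming group lies behind the weaker result.

Benzyloxycarbonyl differs from chloro in several ways at once, bringing a carbonyl, a further aromatic ring and two hydrogen-bond acceptors together, so this single step cannot separate their contributions. As far as these compounds go, whether a carboxylic acid, a methyl ester or an amine at the same place would stay level with compound 2 or fall back towards compound 3 remains open, as does whether the methoxy would matter once the chloro is gone.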